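The source may hold more compounds than are shown below. What is called first, only, known or untested is meant among the compounds shown, and "the series" means these compounds.

Measured compounds in the series:

- compound 1, `Cc1ccc(NC(=O)CN2C(=O)NC3(C2=O)c2ccccc2-c2ccccc23)cc1`: 53.4%
- compound 2, `COc1ccc(NC(=O)CN2C(=O)NC3(C2=O)c2ccccc2-c2ccccc23)cc1`: <= 200%
- compound 3, `O=C(CN1C(=O)NC2(CCCCC2)C1=O)Nc1ccc(Br)cc1`: 85.1%

In a functional assay on the whole organism (strain BALB/c) with Mus musculus as the target, with a stated time of 8 h, at a dose of 10 mg/kg (on this read-out lower numbers stand for less inhibition and higher numbers for more inhibition at the one dose given (going by the name of the read-out)), compound 3 gives 85.1%, the highest of the two numbers shown. The nearest number is that of compound 1, which gives 53.4%, a value lower by a margin beyond the usual scatter. Compound 2 gives only a limit of the assay, <= 200%. The limit is the one marked by the limit of <= 200% in this assay, at which 1 of the 3 values shown sits. For the measured compounds named here, the only one-place step between measured compounds, a step that the limit leaves unreadable from compound 1 to compound 2, is therefore unreadable in size.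

The next compound, compound 4, `Cc1ccc(NC(=O)CN2C(=O)NC3(CCCCC3)C2=O)cc1`, has not yet been measured in this assay. It differs from compound 3 in one place: methyl in place of bromo on an aromatic carbon. Going by the values given here, no measured step concerns an exchange of bromo for methyl, and the single measured step, which concerns methyl and methoxy, cannot be read. Among the compounds with values here, the only numbers to lean on are those of compound 3, which carries bromo on the same core and gives 85.1%, and of compound 1, which carries methyl on a different core and gives 53.4%. Compound 4 is therefore expected to fall between these, at an estimated 68%, with a range from 40% to 92%. The step this estimate means, a number 17.1 percentage points lower from compound 3 to compound 4 (beyond the scatter), is expected to be a modest decrease, close to the edge of the scatter.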

Compound 4, a percentage reported as inhibition, in the whole organism at one dose (the size of the read-out at that dose, not a potency): 70.3%
Beside the measured number, compound 4's estimate is 2.3 percentage points below it; low and high end bracket the measured number.
By their numbers in this assay, from the lowest: compound 1; then compound 4; then compound 3.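

In this assay, for the compounds shown here, the 4-bromophenyl to 4-methylphenyl exchange gives the only step of readable size so far, a number 14.8 percentage points lower from compound 3 to compound 4 (beyond the scatter). The position on the aromatic ring, para to a large group, therefore responds measurably to a change of a single heavy atom, at least on the core shared by these two compounds. Even so, compound 4 keeps a substantial read-out of 70.3% at the one dose, so the exchange reduces the inhibition without removing it, and no measurement shown bears on the cause of this step.

Going by these compounds alone, it remains open whether the same exchange would give a step of similar size on the core of compound 1, as the one step on that core, from compound 1 to compound 2, cannot be read. Also open, as far as these compounds go, is how an amine or a carboxylic acid at this position on the aromatic ring would read, and whether methoxy would hold up on the core shared by compound 3 and compound 4.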